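Thiazol-2-yl in place of tolyl on the amide of compound 2

A few compounds are considered here, and "the series" means these few. Any claim that something is new, unique, unknown or untested is made for them only; others in the source may bear on it.

Measured compounds:
compound 1 `CCCc1cc(OCC(=O)Nc2cc(C)cc(C)c2)c2cc(OC)ccc2n1`: 6.44
compound 2 `COc1ccc2nc(C)cc(OCC(=O)Nc3cccc(C)c3)c2c1`: 4.83

Of the compounds shown here, two sharing a core have so far been measured in a physicochemical assay for lipophilicity, read by HPLC, in phosphate buffer, measured as chromatographic lipophilicity, at pH 7.4; on this read-out higher numbers stand for higher lipophilicity and lower numbers for lower lipophilicity. Compound 1 gives 6.44 and compound 2 gives 4.83. Compound 2 stands lowest of the two numbers; compound 1 lies higher, by a gap beyond the scatter. The next compound, compound 3 `COc1ccc2nc(C)cc(OCC(=O)Nc3nccs3)c2c1`, has not yet been measured. It differs from compound 2 in one place: 1,3-thiazol-2-yl in place of 3-methylphenyl on an amide-type nitrogen. Going by the values given here, no step between measured compounds bears on this change, so the expectation rests on compound 2 alone. In this assay a downward step of fair size is expected, a number 1.23 log units lower from compound 2 to compound 3 (beyond the scatter), because compound 2 gives 4.83 while the group that enters carries two hydrogen-bond acceptors where the group that leaves carried none. Compound 3 is therefore estimated at 3.6, with a range from 3 to 4.2.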

Compound 3, distribution coefficient: 3.2
Compound 3: middle estimate off by 0.40 log units, on the high side; the measured number falls inside the stated range.
By their numbers in this assay, from the lowest: compound 3; then compound 2; then compound 1.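

In this assay, the exchange of 3-methylphenyl for 1,3-thiazol-2-yl on the amide-type nitrogen gives a number 1.63 log units lower from compound 2 to compound 3 (beyond the scatter), the first step read at this position. It shows that the read-out is sensitive to this group, as one exchange there, with the rest of the molecule unchanged, moves the number by a large step beyond the scatter. Nothing shown accounts for the size of this step. The exchange alters ring size, hetero atoms and the methyl group together, so the compounds shown leave open how much of the step belongs to each. A plain phenyl, a pyridin-2-yl or a 1,3-oxazol-2-yl on the same nitrogen would help to separate them, and a propyl chain on the shared core would test whether the step holds there.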